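Acetamido for Trifluoromethyl in a Growth-Inhibition Series

The source may hold more compounds than are shown below. What is called first, only, known or untested is meant among the compounds shown, and "the series" means these compounds.

Measured compounds:
compound 1, `O=S(=O)(NC1=NCCN1C(=S)SN1CCn2c1nsc2=S)c1ccc(C(F)(F)F)cc1`: >= 20000 nM
compound 2, `O=S(=O)(NC1=NCCN1C(=S)SN1CCn2c1nsc2=S)c1cccc(OC(F)(F)F)c1`: >= 20000 nM

Among the compounds with values here, the two compounds measured so far share one core and differ only in the substituent pattern of the sulfonyl-bearing benzene. In a functional assay on KYSE-510 cells (Homo sapiens) for antiproliferative activity, read by crystal violet staining, with a stated time of 96 h (a lower number here means a stronger inhibitor of growth, a higher number a weaker inhibitor of growth), compound 1 gives >= 20000 nM, which is a limit of the assay and not a number. In this assay compound 2 gives >= 20000 nM, again a limit rather than a number. Within the data shown here, compound 1 therefore stands at the edge of what the assay can report, and the one further value shown sits at the same edge, as the limit of >= 20000 nM in this assay, at which 2 of the 2 values shown sit, states. Among the measured compounds shown here, no step between measured compounds can be drawn from such limits.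

Compound 3, `CC(=O)Nc1ccc(S(=O)(=O)NC2=NCCN2C(=S)SN2CCn3c2nsc3=S)cc1`, is the next compound to be tested. It departs from compound 1 by acetamido in place of trifluoromethyl on an aromatic carbon. For the measured compounds named here, with both measured values resting on a limit, there is no measured step that would point in either direction, and nothing beyond the scatter is expected. Compound 3 is estimated to give 20000 nM, within a range from 5000 nM to 80000 nM. The step expected from compound 1 to compound 3 is a number no higher from compound 1 to compound 3 (the limit leaves the size open).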

Compound 3, concentration for 50% growth inhibition: >= 20000 nM
Compound 3: no number, only a limit; the forecaster's own chance of this, stated with the estimate: 70%; the middle value lies on the limit itself.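

In this assay compound 3 gives >= 20000 nM, which is a limit of the assay and not a number. Compound 1 also rests on a limit, so no step between compound 1 and compound 3 can be read, and all the compounds shown stand at one edge: the limit of >= 20000 nM in this assay, at which 3 of the 3 values shown sit.

The compounds shown leave open whether any substituent on the sulfonyl-bearing benzene gives an actual number in this assay.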